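A Mirror-Image Analogue Tested Against Alpha-Mannosidase

This account rests on a few compounds, and the source may have more. Where it says the series, first, only, none or still open, it means among the compounds named here.

Of the compounds shown here, three built on one shared core have been measured in an assay on isolated protein for inhibition of alpha-mannosidase (Canavalia ensiformis), tested at 1000 uM; a lower number here means less inhibition, a higher number more inhibition at the concentration tested (going by the name of the read-out). Compound 1 `CCCCCCCCC[C@]1(CO)NC[C@@H](O)[C@@H]1O` gives 0% in this assay. Compound 2 `COc1cccc([C@]2(CO)NC[C@@H](O)[C@@H]2O)c1` gives 0%, and compound 3 `OC[C@@]1(c2cccc(F)c2)NC[C@@H](O)[C@@H]1O` gives 0%. Compound 2 therefore stands level with compounds 1 and 3 at the digits shown; its nearest neighbour is compound 1 and its furthest is compound 3, and neither gap exceeds the scatter. For the measured compounds named here, the single step between measured compounds that differ in one place, no change at the digits printed from compound 2 to compound 3 (within the scatter), replaces a methoxy with a fluoro on an aromatic carbon and leaves the read-out unmoved.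

Compound 4 `COc1cccc([C@@]2(CO)NC[C@H](O)[C@H]2O)c1` differs from compound 2 in configuration alone: the two compounds have the same atoms and bonds and differ only in configuration as drawn: 3 of 3 stereo elements differ (all stereocentres are inverted: mirror images); a stereocentre at a saturated ring carbon is drawn R in compound 2 and S in compound 4; a stereocentre at a saturated ring carbon is drawn R in compound 2 and S in compound 4; a stereocentre at a saturated ring carbon is drawn R in compound 2 and S in compound 4. Going by the values given here, no measured step inverts a stereocentre, so the one step on record bears on the change only loosely, and it was flat. With every measured compound sitting at the floor of the read-out, the data give no sign that a mirror image would lift inhibition. Compound 4 is therefore expected to give 3%, within a range from 0% to 20%. The expected step of a number 3 percentage points higher from compound 2 to compound 4 (within the scatter) is estimated to stay within the scatter.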

Compound 4, a percentage reported as inhibition, at one concentration (the size of the read-out at that concentration, not a potency): 0%
The estimate for compound 4 lay 3 percentage points above the measured number; low and high end bracket the measured number.
By their numbers in this assay, from the lowest: compounds 1, 2, 3 and 4 (each within the scatter of the next).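

Until now the compounds had differed only in their groups, so configuration had not been tested. In this assay, inverting every stereocentre gives no change at the digits printed from compound 2 to compound 4 (within the scatter), so the mirror-image form of this methoxy compound shows no more inhibition than the original at the concentration tested. Neither compound rises off the floor of the read-out, so the result cannot show whether configuration would matter in a compound that does inhibit the enzyme, although the comparison itself is clean because nothing else separates the pair: the fact that compounds 2 and 4 differ only in the configuration as drawn

From the compounds shown here alone, it remains open whether the configuration of compound 4 would give any inhibition with a different group on the same aromatic carbon, such as an amine or a carboxylic acid in place of the methoxy. Going by these compounds, it is also open whether the two mirror-image forms would separate in an assay where the shared core gives a read-out above the floor.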